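The source may hold more compounds than are shown below. What is called first, only, known or untested is meant among the compounds shown, and "the series" means these compounds.

Measured in an ADME assay on HEK293 cells (Homo sapiens) for cytotoxicity, read by MTT assay, with a stated time of 48 h; a higher number here means a weaker inhibitor, a lower number a stronger inhibitor:
Compound 1 `COc1ccc(N/C(CCNC2=CC(=O)c3ccccc3C2=O)=N\S(=O)(=O)c2ccc(C)cc2)cc1`: 35100 nM
Compound 2 `Cc1ccc(S(=O)(=O)/N=C(/CCNC2=CC(=O)c3ccccc3C2=O)Nc2ccccc2I)cc1`: 49400 nM

Compound 2 and compound 1 sit within the scatter of each other, so neither can be called the weaker or stronger. Compound 3 `Cc1ccc(S(=O)(=O)/N=C(/CCNC2=CC(=O)c3ccccc3C2=O)Nc2cccc(C(F)(F)F)c2)cc1` differs from compound 2 by 3-(trifluoromethyl)phenyl in place of 2-iodophenyl on an amine nitrogen. Going by the values given here, the one comparable step, an aryl swap on that same amine nitrogen, gave a 1.4-fold higher number from compound 1 to compound 2 (0.15 log units; within the scatter). On that basis compound 3 is expected to show a 1.1-fold lower number from compound 2 to compound 3 (0.04 log units; within the scatter), nothing beyond the scatter. The estimate for compound 3 in this assay is 45000 nM, with a range from 20000 nM to 100000 nM.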

Compound 3, half-maximal inhibitory concentration: 91500 nM
Beside the measured number, compound 3's estimate is 2.0-fold (0.31 log units) below it; the measured number falls inside the stated range.
By their numbers in this assay, from the lowest: compounds 1, 2 and 3 (each within the scatter of the next, the first and the last beyond it).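

In this assay the aryl group on this amine nitrogen now gives a step beyond the scatter, a 2.6-fold higher number from compound 1 to compound 3 (0.42 log units; beyond the scatter) and modest in size, which the earlier pair did not show. Yet a 1.9-fold higher number from compound 2 to compound 3 (0.27 log units; within the scatter) does not clear the scatter, so 3-(trifluoromethyl)phenyl separates from 4-methoxyphenyl but not from 2-iodophenyl. Nothing available explains this difference.

On these data alone, whether a phenyl group carrying an amine or a carboxylic acid, or a saturated cyclohexyl ring in place of the phenyl, would move the number further remains open.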